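Swapping the aryl group on a naphthyloxy acetohydrazone

A few compounds are considered here, and "the series" means these few. Any claim that something is new, unique, unknown or untested is made for them only; others in the source may bear on it.

Measured compounds:
compound 1 `O=C(COc1cccc2ccccc12)N/N=C/c1c(O)ccc2ccccc12` gives 4.74
compound 2 `O=C(COc1cccc2ccccc12)N/N=C/c1ccccc1Br` gives 4.81
compound 3 `C/C(=N\NC(=O)COc1cccc2ccccc12)c1ccccc1Br` gives 4.44

These three compounds share a common core and were measured in a physicochemical assay for lipophilicity, measured as octanol-water partition; a lower number here means a more polar compound, a higher number a more lipophilic compound. Compound 2 has the largest of the three numbers, yet compound 1 stands within the scatter of it, so the two cannot be told apart; compound 3 lies beyond the scatter, with a lower number. The whole span covered by the three compounds is modest.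

Compound 4 `CSc1ccc(/C=N/NC(=O)COc2cccc3ccccc23)cc1` has not yet been measured. It differs from compound 2 in one place: 4-(methylsulfanyl)phenyl in place of 2-bromophenyl on a carbon with a double bond to nitrogen. Among the measured compounds shown here, no measured pair in this set shows the effect of such a swap, so there is no direct step to lean on.

The step of a number 0.26 log units lower from compound 2 to compound 4 (within the scatter) is expected to be small and downward, probably close to the edge of the scatter. In this assay compound 4 is therefore estimated at 4.55, with a range from 4.15 to 4.95.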

Compound 4, partition coefficient: 4.11
Compound 4: the middle estimate sits 0.44 log units above what was measured; measured number outside the range, below it.
By their numbers in this assay, from the lowest: compound 4; then compounds 3, 1 and 2 (each within the scatter of the next, the first and the last beyond it).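

In this assay, among the compounds shown here, replacing 2-bromophenyl with 4-(methylsulfanyl)phenyl on a carbon with a double bond to nitrogen gives a number 0.70 log units lower from compound 2 to compound 4 (beyond the scatter), the first step in this set that can be read across a single change. It shows that the number responds to what sits at this position, with a step that lies beyond the scatter even though the group changes by only one heavy atom. Nothing measured here explains the size of this step.

The swap changes both the substituent, bromine against methylsulfanyl, and the number in the group's name, so the compounds shown cannot divide the step between these two differences. As far as these compounds go, how this assay would respond to a phenyl group carrying an amine or a carboxylic acid at this same place also remains open.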